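Notes on the amide series: compound 4 to be measured

A few compounds are considered here, and "the series" means these few. Any claim that something is new, unique, unknown or untested is made for them only; others in the source may bear on it.

Within the data shown here, compound 1 `O=C(Nc1cc(-c2ccccc2)nn1-c1ccccc1)c1cccc([N+](=O)[O-])c1` is one of only two compounds here with a number in an assay on HEK293 cells for displacement of a labelled ligand from metabotropic glutamate receptor 5 (Rattus norvegicus); a lower number here means a stronger inhibitor, a higher number a weaker inhibitor; compound 1 gives 2220 nM. Compound 3 `O=C(Nc1cc(-c2ccccc2)nn1-c1ccccc1Br)c1ccccc1` gives 2600 nM in this assay, a value within the scatter of that of compound 1, so the two cannot be ordered. Compound 2 `O=C(Nc1cc(-c2ccccc2)nn1-c1ccccc1)c1cc([N+](=O)[O-])cc([N+](=O)[O-])c1` has no result in this assay, reported as "not determined" (no result reported). Compound 4 `Cc1ccc(C(=O)Nc2cc(-c3ccccc3)nn2-c2ccccc2)cn1` differs from compound 1 by 6-methylpyridin-3-yl in place of 3-nitrophenyl on a carbonyl carbon. Among the measured compounds shown here, no measured pair in this set shares that change, so it offers no direct guide. The step of a 1.5-fold lower number from compound 1 to compound 4 (0.17 log units; within the scatter) is expected to be modest, with no strong reason to look far beyond the scatter in either direction. Compound 4 is therefore expected to show about 1500 nM in this assay, within 400 nM to 6000 nM.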

Compound 4, inhibition constant: 3480 nM
Beside the measured number, compound 4's estimate is 2.3-fold (0.37 log units) below it; measured number inside the range.
By their numbers in this assay, from the lowest: compounds 1, 3 and 4 (each within the scatter of the next).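

In this assay, 6-methylpyridin-3-yl in place of 3-nitrophenyl on a carbonyl carbon gives a 1.6-fold higher number from compound 1 to compound 4 (0.20 log units; within the scatter), the first step read at this position. In this one pair, the position takes a ring with a hetero atom and no nitro group without a change beyond the scatter. No evidence here bears on this result.

The ring and its substituent change together, so this pair cannot separate them. As far as these compounds go, whether an amine, a carboxylic acid or a longer chain in place of the methyl would move the number beyond the scatter remains open.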